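Extending the alkyl chain of an amino-diol sphingoid analog

The source may report more compounds than this note shows. Statements on the series, on what has been measured and on what is new or still open speak of the compounds shown alone.

Measured so far:
- compound 1, `CCCCCCCCCCCCCCCCCC[C@@H](N)[C@@H](O)CO`: 10600 nM
- compound 2, `CCCCCCCCCCCCCC[C@H](N)[C@H](O)CO`: 2860 nM

In a functional assay on Lewis lung carcinoma cells for inhibition, with Lewis lung carcinoma cell line (Mus musculus) as the target (a higher number here means a weaker inhibitor, a lower number a stronger inhibitor), compound 2 gives the lower of the two numbers, and its gap to compound 1 lies beyond the usual scatter. Compound 3, `CCCCCCCCCCCCCCCCCC[C@H](N)[C@H](O)CO`, has not been measured yet. It differs from compound 2 by butyl in place of hydrogen on a saturated chain carbon, ten or more bonds along the chain from an amine nitrogen, so the change sits far from the amine and the two hydroxyl groups. Within the data shown here, no directly comparable step is available among the measured pair, and the only other compound that carries the longer chain, compound 1, differs from compound 3 in its stereochemistry as well, so it cannot settle the question on its own. A moderate weakening is expected rather than a gain, in line with the higher number of compound 1 at 10600 nM. Compound 3 is therefore estimated at 6000 nM, with a range of 2500 nM to 15000 nM, meaning an expected step of a 2.1-fold higher number from compound 2 to compound 3 (0.32 log units; beyond the scatter) in this assay.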

Compound 3, half-maximal inhibitory concentration: 3470 nM
Beside the measured number, compound 3's estimate is 1.7-fold (0.24 log units) above it; low and high end bracket the measured number.
By their numbers in this assay, from the lowest: compounds 2 and 3 (each within the scatter of the next); then compound 1.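

In this assay, butyl in place of hydrogen on a saturated chain carbon, ten or more bonds along the chain from an amine nitrogen, gives a 1.2-fold higher number from compound 2 to compound 3 (0.08 log units; within the scatter) and so leaves compounds 2 and 3 indistinguishable. At this far stretch of the chain, then, the added length shows no measurable effect in this cell assay. The clear gap lies elsewhere, in a 3.1-fold lower number from compound 1 to compound 3 (0.48 log units; beyond the scatter) for two compounds with the same chain, and that gap can be assigned to stereochemistry because of this: the fact that compounds 1 and 3 differ only in the configuration as drawn

On these data alone, whether the same mirror-image gap appears at the shorter chain of compound 2 remains open. So does whether a much shorter chain, such as octyl, or a phenyl ring at the chain end would keep these numbers.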